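The source may hold more compounds than are shown below. What is called first, only, known or untested is meant among the compounds shown, and "the series" means these compounds.

Of the compounds shown here, three have been measured so far. Compound 1 `CC[C@@H]1C(=O)N(C)c2cnc(Nc3ccc(S(=O)(=O)NC4CCCC4)cc3)nc2N1C1CCCC1` gives 688 nM in a functional assay on MCF7 cells (Homo sapiens) for antiproliferative activity, read by CCK-8 assay, with a stated time of 72 h (on this read-out lower numbers stand for stronger inhibition of growth and higher numbers for weaker inhibition of growth), the lowest of the three numbers. Compound 2 `CC[C@@H]1C(=O)N(C)c2cnc(-n3ccc4cc(C(=O)NCC(C)C)ccc43)nc2N1C1CCCC1` gives 953 nM in this assay, a value within the scatter of compound 1, so no order between the two can be claimed. Compound 3 `CCC1C(=O)N(C)c2cnc(Nc3ccc(S(=O)(=O)NC)cc3)nc2N1c1ccn(C)n1` gives 3750 nM in this assay, a number beyond the scatter from compound 1. Compound 4 `CC[C@@H]1C(=O)N(C)c2cnc(Nc3ccc(S(=O)(=O)NC)cc3)nc2N1C1CCCC1` has not yet been measured. It differs from compound 1 in one place: methyl in place of cyclopentyl on a sulfonamide nitrogen. Among the measured compounds shown here, no measured pair shows this change by itself, so its size is open. A small loss of potency is expected, with a step estimated at a 1.9-fold higher number from compound 1 to compound 4 (0.28 log units; within the scatter), close to the edge of the scatter. Compound 4 is expected to give 1300 nM, within a range of 500 nM to 3500 nM.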

Compound 4, concentration for 50% growth inhibition: 151 nM
For compound 4 the middle estimate is 8.6-fold (0.93 log units) above the measured one; the whole stated range lies above it.
By their numbers in this assay, from the lowest: compound 4; then compounds 1 and 2 (each within the scatter of the next); then compound 3.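

In this assay, among the compounds shown here, putting methyl in place of cyclopentyl on a sulfonamide nitrogen gives a 4.6-fold lower number from compound 1 to compound 4 (0.66 log units; beyond the scatter) and so provides the first direct reading of this position. The cyclopentyl ring is therefore not needed here for growth inhibition, and the change improves on compound 1 rather than costing potency. No measurement at hand explains why the number falls with this change.

On these data alone, only cyclopentyl and methyl can be compared on this nitrogen, so it remains open where an ethyl group, a longer chain or a terminal amine would fall. As far as these compounds go, whether methyl is the best group here also remains open.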